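Aryl sulfone swap on a fluoroquinoline core

A few compounds are considered here, and "the series" means these few. Any claim that something is new, unique, unknown or untested is made for them only; others in the source may bear on it.

Two close analogues have been measured in an assay on isolated protein for displacement of a labelled ligand from metabotropic glutamate receptor 5 (Homo sapiens), with a stated time of 60 min, tested at 1 uM; on this read-out higher numbers stand for more inhibition at the one concentration tested (going by the name of the read-out) and lower numbers for less inhibition. Compound 1 `Cc1ccc(S(=O)(=O)c2cnc3ccc(F)cc3c2N2CCC(C)CC2)cc1C` gives 92%. Going by the values given here, compound 2 `CC1CCN(c2c(S(=O)(=O)c3ccc(Cl)c(Cl)c3)cnc3ccc(F)cc23)CC1` gives 91%, the lower of the two numbers, yet the only step that joins them, a number 1 percentage points lower from compound 1 to compound 2 (within the scatter), falls within the scatter, so the two compounds cannot be set in order. The next compound, compound 3 `COc1cccc(S(=O)(=O)c2cnc3ccc(F)cc3c2N2CCC(C)CC2)c1`, has not been measured. It departs from compound 2 in one place: 3-methoxyphenyl in place of 3,4-dichlorophenyl on a sulfonyl sulfur. Among the compounds with values here, the one measured step bears on this change only loosely, since it exchanged one aryl group for another on the same sulfonyl sulfur without a shift beyond the scatter. On that basis no large step is expected, though a single precedent is a thin footing. Compound 3 is therefore estimated at 84%, with a range from 62% to 97%, corresponding to an expected step of a number 7 percentage points lower from compound 2 to compound 3 (within the scatter).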

Compound 3, a percentage reported as inhibition, at one concentration (the size of the read-out at that concentration, not a potency): 90%
The estimate for compound 3 lay 6 percentage points below the measured number; the range from low to high includes it.
By their numbers in this assay, from the lowest: compounds 3, 2 and 1 (each within the scatter of the next).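

Replacing the 3,4-dichlorophenyl group on the sulfonyl sulfur with 3-methoxyphenyl gives a number 1 percentage points lower from compound 2 to compound 3 (within the scatter) in this assay and replacing the 3,4-dimethylphenyl group with it gives a number 2 percentage points lower from compound 1 to compound 3 (within the scatter) in the same assay. The earlier pair showed level numbers only between two 3,4-disubstituted phenyl groups without oxygen, whereas the entering group here carries an oxygen and a hydrogen-bond acceptor, and the three compounds still cannot be set in order. No measurement shown offers an explanation for this result.

On these data alone, it remains open whether a carboxylic acid or an amine on this phenyl ring would move the number beyond the scatter. A single concentration also leaves open whether these three compounds differ in potency.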